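The source may report more compounds than this note shows. Statements on the series, on what has been measured and on what is new or still open speak of the compounds shown alone.

Compound 1 `CCc1nc(C(=O)OC)nn1-c1ccc(F)cc1` gives 11000 nM in a functional assay on Jurkat cells (Homo sapiens) for inhibition, read by MTT assay, with a stated time of 72 h; on this read-out higher numbers stand for weaker inhibition of growth and lower numbers for stronger inhibition of growth.
Compound 2 `COC(=O)c1nc(C(C)C)n(-c2ccc(F)cc2)n1` reaches only a limit of this assay, > 100000 nM, and not a number.
Compound 3 `COC(=O)c1nc(C2CC2)n(-c2ccc(F)cc2)n1` gives 9420 nM in this assay.

Compound 3 stands together with compound 1, since the step of a 1.2-fold lower number from compound 1 to compound 3 (0.07 log units; within the scatter) lies within the scatter, and apart from the limit of compound 2. Compound 4 `COC(=O)c1nc(C2CCCC2)n(-c2ccc(F)cc2)n1` differs from compound 3 by cyclopentyl in place of cyclopropyl on an aromatic carbon. Among the compounds with values here, two measured steps bear on this change in size at that aromatic carbon: an at least 10-fold lower number from compound 2 to compound 3 (1.02 log units; beyond the scatter) and an at least 9.0-fold higher number from compound 1 to compound 2 (0.95 log units; beyond the scatter). Both show the bulkier group on that carbon giving the higher number, the limit of > 100000 nM in this assay, at which 1 of the 3 values shown sits, marking the upper end. Cyclopentyl is the largest group of the set, so a rise beyond the scatter is expected for compound 4, a 3.7-fold higher number from compound 3 to compound 4 (0.57 log units; beyond the scatter). Compound 4 is therefore estimated at 35000 nM, between 9000 nM and 100000 nM.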

Compound 4, concentration for 50% growth inhibition: 9550 nM
Beside the measured number, compound 4's estimate is 3.7-fold (0.56 log units) above it; measured number inside the range.
By their numbers in this assay, from the lowest: compounds 3, 4 and 1 (each within the scatter of the next). At a limit, above all of these: compound 2.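

In this assay cyclopentyl on this aromatic carbon stands level with cyclopropyl (a 1.0-fold higher number from compound 3 to compound 4 (0.01 log units; within the scatter)) and with ethyl (a 1.2-fold lower number from compound 1 to compound 4 (0.06 log units; within the scatter)), so the larger ring does not by itself raise the number. Only compound 2, with isopropyl, stays apart (an at least 10-fold lower number from compound 2 to compound 4 (1.01 log units; beyond the scatter)). The value of compound 2 is a limit and not a number.

The compounds shown leave open whether cyclobutyl or cyclohexyl on this carbon would stay level with compound 3 and compound 4, or whether tert-butyl would reach a limit as compound 2 does. They also leave open what an amine or a carboxylic acid in place of the methoxycarbonyl group would give.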